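Removing a hydroxymethyl from compound 2

A few compounds are considered here, and "the series" means these few. Any claim that something is new, unique, unknown or untested is made for them only; others in the source may bear on it.

Measured in an ADME assay on CHO cells (Cricetulus griseus) for cytotoxicity, read by MTT assay; a higher number here means a weaker inhibitor, a lower number a stronger inhibitor:
Compound 1 `CS(=O)(=O)c1cccc(Nc2ccc3nccc(-c4ccncc4)c3n2)c1`: > 50000 nM, a limit of the assay
Compound 2 `O=S(=O)(CCO)c1cccc(-c2ccc3nccc(-c4ccncc4)c3n2)c1`: 26000 nM
Compound 3 `O=S(=O)(NCCO)c1cccc(Nc2ccc3nccc(-c4ccncc4)c3n2)c1`: 4000 nM

Of the two results in this assay that are actual numbers, compound 2 holds the higher at 26000 nM. Compound 3 lies clearly lower at 4000 nM. Compound 1 is reported only as a limit, > 50000 nM.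

Compound 4 `CS(=O)(=O)c1cccc(-c2ccc3nccc(-c4ccncc4)c3n2)c1` has not yet been measured. It differs from compound 2 by hydrogen in place of hydroxymethyl on a saturated chain carbon bound to a sulfonyl sulfur, with hydrogen in place of hydroxymethyl on a saturated chain carbon bound to a sulfonyl sulfur, so that 2-hydroxyethyl becomes methyl.

Within the data shown here, one measured step bears on this: an at least 12-fold lower number from compound 1 to compound 3 (1.09 log units; beyond the scatter). That step is large, but its change is not the same as the present one. Read in reverse, it points towards a higher number when methyl is reached, and it does not fix the size. Only a small rise is therefore expected, probably within the scatter, and the expected change is a 1.2-fold higher number from compound 2 to compound 4 (0.06 log units; within the scatter). A report of only a limit is also possible.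

For compound 4 the estimated value is 30000 nM, with an expected range from 12000 nM to 50000 nM.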

Compound 4, half-maximal inhibitory concentration: 13000 nM
Estimate against measurement, compound 4: 2.3-fold (0.36 log units) above; the range from low to high includes it.
By their numbers in this assay, from the lowest: compound 3; then compounds 4 and 2 (each within the scatter of the next). At a limit, above all of these: compound 1.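

In this assay the loss of the hydroxymethyl on the saturated chain carbon bound to the sulfonyl sulfur gives a 2.0-fold lower number from compound 2 to compound 4 (0.30 log units; within the scatter), so this assay does not tell 2-hydroxyethyl and methyl apart at this place. This step has an actual number at both ends, and it shows that the chain on the sulfonyl sulfur can go from 2-hydroxyethyl to methyl without a change beyond the scatter. Among these compounds, the one other step at the sulfonyl sulfur, an at least 12-fold lower number from compound 1 to compound 3 (1.09 log units; beyond the scatter), exchanges methyl for (2-hydroxyethyl)amino and starts from a limit, so its full size stays unknown: the limit of > 50000 nM in this assay, at which 1 of the 4 values shown sits.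

What remains open is whether (2-hydroxyethyl)amino on the sulfonyl sulfur would also lower the number on the core of compound 4, since no pair shown tests that exchange there. Also open, going by these compounds, is how a longer chain, an amine or a carboxylic acid at this place would read in this assay, as the two groups compared so far cover only 2-hydroxyethyl and methyl.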